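A few compounds are considered here, and "the series" means these few. Any claim that something is new, unique, unknown or untested is made for them only; others in the source may bear on it.

Series notes. Three amides of the shared core carry a dithiocarbamate-linked cyclic amine and have been run through a functional assay on MGC-803 cells (Homo sapiens) for antiproliferative activity, read by CCK-8 assay, with a stated time of 72 h, tested at 8 uM; on this read-out lower numbers stand for a weaker effect and higher numbers for a stronger effect at the one concentration tested. Compound 1, `Nc1ccccc1NC(=O)c1ccc(CSC(=S)N2CCN(C(c3ccccc3)c3ccccc3)CC2)cc1`, gives 9.9%. Compound 2, `Nc1ccccc1NC(=O)c1ccc(CSC(=S)N2CCN(c3ccc(Cl)cc3)CC2)cc1`, gives 17.2%. Compound 3, `Nc1ccccc1NC(=O)c1ccc(CSC(=S)N2CCc3ccccc32)cc1`, gives 87%. On these three numbers compound 2 sits close to compound 1, with a gap that stays within the scatter, and far beneath compound 3, whose gap to compound 2 lies beyond the scatter. The two piperazine compounds thus sit together at the low end of this assay, while the indoline compound 3 stands apart.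

Compound 4, `Nc1ccccc1NC(=O)c1ccc(CSC(=S)N2CCN(c3cccnc3)CC2)cc1`, has not yet been measured. Compared with compound 2 the change is pyridin-3-yl in place of 4-chlorophenyl on an amine nitrogen in a ring. For the measured compounds named here, both aryl-piperazine compounds measured so far give low numbers in this assay, so no step beyond the scatter is expected in either direction; the expected step from compound 2 to compound 4 is a number 2.2 percentage points lower from compound 2 to compound 4 (within the scatter). For compound 4 the estimated value in this assay is 15%, with a range from 3% to 35%.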

Compound 4, a percentage reported as inhibition, at one concentration (the size of the read-out at that concentration, not a potency): 76.9%
For compound 4 the middle estimate is 61.9 percentage points below the measured one; measured number above the stated range.
By their numbers in this assay, from the lowest: compounds 1 and 2 (each within the scatter of the next); then compound 4; then compound 3.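

Working notes on the amine nitrogen in the ring: the aryl group at this position can shift the read-out strongly, a point the earlier compounds did not show. In this assay the change to pyridin-3-yl in place of 4-chlorophenyl gives a number 59.7 percentage points higher from compound 2 to compound 4 (beyond the scatter) and counts as a large step, so a low number for one aryl-piperazine does not carry over to another. No measurement at hand bears on the reason for this step.

The step removes the chlorine and places a nitrogen in the aromatic ring in a single change, so an unsubstituted phenyl on the same nitrogen would be needed to separate the two. On these data alone, how pyridin-2-yl or pyridin-4-yl would compare with pyridin-3-yl at this position also remains open.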